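A Trifluoromethyl Group Added to Compound 2

The source may hold more compounds than are shown below. What is called first, only, known or untested is meant among the compounds shown, and "the series" means these compounds.

Measured in a functional assay on NCI-H460 cells (Homo sapiens) for inhibition, read by MTT assay, with a stated time of 24 h, tested at 0.1 ug/mL (on this read-out higher numbers stand for more inhibition of growth at the one concentration tested and lower numbers for less inhibition of growth), so far:
- compound 1 `O=C(CCCCC(S)CCS)NO` gives 5.7%
- compound 2 `O=C(CCCCC(S)CCS)Nc1ccccc1` gives 5.5%
- compound 3 `O=C(CCCCC(S)CCS)Nc1ccc(F)cc1` gives 5.64%

Compound 2 stands level with the other two, since its steps to both stay within the scatter. Compound 4 `O=C(CCCCC(S)CCS)Nc1cccc(C(F)(F)F)c1` carries trifluoromethyl in place of hydrogen on an aromatic carbon. The closest measured change, fluoro in place of hydrogen on an aromatic carbon, gave a number 0.1 percentage points higher from compound 2 to compound 3 (within the scatter) and swapping hydroxy for phenyl gave a number 0.2 percentage points lower from compound 1 to compound 2 (within the scatter) as well. Among the compounds with values here, only one such ring change has been measured, so the basis is thin. The expected change in this assay is therefore none beyond the scatter, an estimated a number 0.5 percentage points higher from compound 2 to compound 4 (within the scatter) here. Compound 4 is expected to give 6%, with an estimated range from 1% to 15% in this measurement.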

Compound 4, percent growth inhibition at one concentration: 12%
The estimate for compound 4 lay 6 percentage points below the measured number, and the stated range covers the measured number.
By their numbers in this assay, from the lowest: compounds 2, 3, 1 and 4 (each within the scatter of the next).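

Placed on the ring carbon meta to a large group, trifluoromethyl brings 4 heavy atoms where there was only hydrogen, yet this assay gives a number 6.5 percentage points higher from compound 2 to compound 4 (within the scatter). So a substituent much bulkier than a single fluoro also leaves the read-out within the usual scatter at the one concentration tested. Nothing available here bears on why this ring change has so little effect.

From the compounds shown here alone, whether an amine or a carboxylic acid on this ring carbon would move the number beyond the scatter remains open. So does the behaviour of trifluoromethyl on other ring carbons.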